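Chloro to amino on the shared core

This account rests on a few compounds, and the source may have more. Where it says the series, first, only, none or still open, it means among the compounds named here.

In a functional assay on HCT-116 cells (Homo sapiens) for antiproliferative activity, read by MTT assay, with a stated time of 48 h (a lower number here means a stronger inhibitor, a higher number a weaker inhibitor), compound 1 `CCCCCC(CCO)n1cnc2c(Cl)nc(F)nc21` gives 8660 nM and compound 2 `CCCCCC(CCO)n1cnc2c(Cl)nc(Cl)nc21` gives 6170 nM so compound 2 stands level with compound 1 within the scatter. Compound 3 `CCCCCC(CCO)n1cnc2c(N)nc(Cl)nc21` differs from compound 2 by amino in place of chloro on an aromatic carbon with amino in place of chloro on an aromatic carbon. Going by the values given here, the only measured step, a 1.4-fold lower number from compound 1 to compound 2 (0.15 log units; within the scatter) as chloro replaces fluoro, lies within the scatter and concerns a different carbon, so it offers weak guidance. A moderate move to a higher number is expected, as a judgement with wide uncertainty. The estimated step is a 2.3-fold higher number from compound 2 to compound 3 (0.36 log units; beyond the scatter) in this series. Compound 3 is estimated at 14000 nM with an expected range of 5000 nM to 35000 nM in this read-out.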

Compound 3, half-maximal inhibitory concentration: > 50000 nM
Compound 3: a limit, no number (the forecaster's own chance of this, stated with the estimate: 10%); at least 3.5-fold (0.55 log units) between middle value and limit.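

In this assay, amino in place of chloro on this aromatic carbon, next to the ring nitrogen, gives an at least 8.1-fold higher number from compound 2 to compound 3 (0.90 log units; beyond the scatter). Going by these compounds alone, this shows that the position responds to a change of group, whereas the only earlier step, a 1.4-fold lower number from compound 1 to compound 2 (0.15 log units; within the scatter), concerned a different carbon. Compound 3 gives a limit, not a number: the limit of > 50000 nM in this assay, at which 1 of the 3 values shown sits.

From the compounds shown here alone, how far compound 3 lies past that limit stays open. So does the outcome with a methoxy, methylamino or hydroxyl group on this carbon, which would show whether the drop is peculiar to amino.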